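The source may hold more compounds than are shown below. What is called first, only, known or untested is meant among the compounds shown, and "the series" means these compounds.

Three anilinoquinazoline sulfonamides have been compared in a functional assay on A-431 cells (Homo sapiens) for antiproliferative activity, read by MTT assay, with a stated time of 72 h; a lower number here means a stronger inhibitor, a higher number a weaker inhibitor. Compound 1 `COc1cc2ncnc(Nc3ccc(Cl)c(C(F)(F)F)c3)c2cc1OCCCCC(=O)Nc1ccc(S(N)(=O)=O)cc1` gives 3910 nM, compound 2 `COc1cc2ncnc(Nc3ccc(Cl)cc3)c2cc1OCCCCC(=O)Nc1ccc(S(N)(=O)=O)cc1` gives 7120 nM, and compound 3 `COc1cc2ncnc(Nc3cc(F)c(F)c(F)c3)c2cc1OCCCCC(=O)Nc1ccc(S(N)(=O)=O)cc1` gives 23400 nM. Compound 3 therefore holds the highest number of the three: the step of a 3.3-fold higher number from compound 2 to compound 3 (0.52 log units; beyond the scatter) lies beyond the scatter, as does a 6.0-fold higher number from compound 1 to compound 3 (0.78 log units; beyond the scatter), while a 1.8-fold higher number from compound 1 to compound 2 (0.26 log units; within the scatter) stays within it.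

Compound 4 `COc1cc2ncnc(Nc3ccc(C)cc3)c2cc1OCCCCC(=O)Nc1ccc(S(N)(=O)=O)cc1` is now in question. It differs from compound 3 by 4-methylphenyl in place of 3,4,5-trifluorophenyl on a nitrogen on an aromatic ring. Two of the measured steps bear on this change, since both run from a phenyl carrying a single group on the nitrogen to the 3,4,5-trifluorophenyl: a 3.3-fold higher number from compound 2 to compound 3 (0.52 log units; beyond the scatter) and a 6.0-fold higher number from compound 1 to compound 3 (0.78 log units; beyond the scatter). Reversing that pattern, a 4-methylphenyl in place of the 3,4,5-trifluorophenyl is expected to move the number back downward by a modest amount, roughly the size of a 2.9-fold lower number from compound 3 to compound 4 (0.47 log units; beyond the scatter). Compound 4 is accordingly estimated at 8000 nM in this assay, with a likely range from 3000 nM to 25000 nM.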

Compound 4, half-maximal inhibitory concentration: 35500 nM
Beside the measured number, compound 4's estimate is 4.4-fold (0.65 log units) below it; the measured number lies above the stated range.
By their numbers in this assay, from the lowest: compounds 1 and 2 (each within the scatter of the next); then compounds 3 and 4 (each within the scatter of the next).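

Swapping in the 4-methylphenyl does not restore the lower numbers: on this nitrogen it cannot be told apart from the 3,4,5-trifluorophenyl (a 1.5-fold higher number from compound 3 to compound 4 (0.18 log units; within the scatter)), so a single group on the ring is not what separates compound 2 from compound 3. Methyl in place of chloro is a step beyond the scatter on its own (a 5.0-fold higher number from compound 2 to compound 4 (0.70 log units; beyond the scatter)), and the step from the ring carrying both chloro and trifluoromethyl also lies beyond it (a 9.1-fold higher number from compound 1 to compound 4 (0.96 log units; beyond the scatter)). Among these four, the two compounds with a chloro group hold the lower numbers, and none goes against that.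

As far as these compounds go, whether chloro itself matters, or bromo or a methoxy group in its place would serve as well, remains open. Nothing available explains why methyl and chloro differ here.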